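Lactam Replacement of a Hydroxymethyl Arm on a Piperazine Series

This account rests on a few compounds, and the source may have more. Where it says the series, first, only, none or still open, it means among the compounds named here.

Of the compounds shown here, two have been measured in an assay on isolated protein for displacement of a labelled ligand from Alpha-1B adrenergic receptor (Homo sapiens); on this read-out lower numbers stand for stronger inhibition and higher numbers for weaker inhibition. Compound 1, `OCc1cc(CN2CCN(c3ccccc3Oc3ccccc3)CC2)on1`, gives 3720 nM in this assay. Compound 2, `CC(C)Oc1ccccc1N1CCN(Cc2cc(CN3CCCC3=O)no2)CC1`, gives 2990 nM in this assay. Going by the values given here, compound 1 carries the highest of the two numbers, and the gap to compound 2 lies within the scatter of the method, so the two stand on the same footing; compound 2 differs from compound 1 in more than one place, and no single step between them can be read.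

The change now under consideration leads from compound 1 to compound 3, `O=C1CCCCN1Cc1cc(CN2CCN(c3ccccc3Oc3ccccc3)CC2)on1`. The difference reads (2-oxopiperidin-1-yl in place of hydroxy on a saturated chain carbon bound to an aromatic carbon). The hydroxy group carried a donor; the entering ring carries none and keeps one acceptor.

With no measured step of this kind in the series, the expectation for compound 3 is a step from compound 1 that stays near or within the scatter, with at most a modest move toward a lower number, so that a 1.5-fold lower number from compound 1 to compound 3 (0.17 log units; within the scatter) is the expected change. Compound 3 is therefore expected to give about 2500 nM in this assay, with a range from 800 nM to 8000 nM.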

Compound 3, inhibition constant: 2210 nM
Compound 3: the middle estimate sits 1.1-fold (0.05 log units) above what was measured, within the range that was stated.
By their numbers in this assay, from the lowest: compounds 3, 2 and 1 (each within the scatter of the next).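

The series now has its first step that can be read in this assay: with 2-oxopiperidin-1-yl in place of hydroxy on a saturated chain carbon bound to an aromatic carbon, the result is a 1.7-fold lower number from compound 1 to compound 3 (0.23 log units; within the scatter). At this position, then, the hydroxy group with its hydrogen-bond donor can give way to a six-membered non-aromatic ring with no donor, and the number does not leave the scatter of the method. No independent measurement bears on why the read-out stays at this level.

The steps that would link compound 2 to compound 1 or compound 3 cannot be read, since compound 2 differs from each of them in more than one place, so the shared core of compound 1 and compound 3 remains the only setting in which this exchange can be judged. The compounds shown leave open whether an amine, a carboxylic acid or a longer chain on this same carbon would move the number beyond the scatter, or whether this position stays as flat across such groups as this one step suggests.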